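Alkynyl uracil series: benzyl against 4-bromophenyl

The source may hold more compounds than are shown below. What is called first, only, known or untested is meant among the compounds shown, and "the series" means these compounds.

Compound 1 `CC(=O)OCC(CCn1cc(C#Cc2ccc(Br)cc2)c(=O)n(C(=O)c2ccccc2)c1=O)COC(C)=O`: in a functional assay on SW-620 cells (Homo sapiens) for antiproliferative activity, read by MTT assay, with a stated time of 72 h (on this read-out lower numbers stand for stronger inhibition and higher numbers for weaker inhibition), compound 1 gives > 100000 nM.
Compound 2 `CC(=O)OCC(CCn1cc(C#CCc2ccccc2)c(=O)n(C(=O)c2ccccc2)c1=O)COC(C)=O`: in this assay compound 2 gives 36400 nM.
Compound 3 `O=c1[nH]c(=O)n(CCC(CO)CO)cc1C#Cc1ccc(Br)cc1`: in this assay compound 3 gives > 100000 nM.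

The value of compound 1 is a limit of the assay, not a number. The value of compound 3 is likewise a limit; two of the three values sit at the limit of > 100000 nM in this assay, at which 2 of the 3 values shown sit. Compound 4 `O=c1[nH]c(=O)n(CCC(CO)CO)cc1C#CCc1ccccc1` has not been measured in this assay.

The change from compound 1 to compound 2 is benzyl in place of 4-bromophenyl on a triple-bonded carbon, and it gave an at least 2.7-fold lower number from compound 1 to compound 2 (0.43 log units; beyond the scatter). The cores of compound 1 and compound 3 differ in more than one place; the difference between the two cores is not broken down here. Compound 4 carries the same change on the core of compound 3, (benzyl in place of 4-bromophenyl on a triple-bonded carbon), at the same place, so the change is the same.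

Compound 4 is expected to stand an at least 1.6-fold lower number from compound 3 to compound 4 (0.22 log units; that floor lies within the scatter), because the same change gave an at least 2.7-fold lower number from compound 1 to compound 2 (0.43 log units; beyond the scatter). Compound 4 is therefore estimated at 60000 nM, between 25000 nM and 150000 nM, and a limit rather than a number remains quite possible.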

Compound 4, half-maximal inhibitory concentration: 72400 nM
Estimate against measurement, compound 4: 1.2-fold (0.08 log units) below; the range from low to high includes it.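

In this assay, benzyl in place of 4-bromophenyl on a triple-bonded carbon gave an at least 1.3-fold lower number from compound 3 to compound 4 (0.14 log units; that floor lies within the scatter). Compound 3 gives > 100000 nM, which is a limit and not a number. Both cores show a lower number with benzyl, although the floor of the new step does not clear the scatter, so the data support only a shared direction on these two cores and not a shared size: the same change on two cores in this assay, an at least 2.7-fold lower number (0.43 log units; beyond the scatter) from compound 1 to compound 2 and an at least 1.3-fold lower number (0.14 log units; that floor lies within the scatter) from compound 3 to compound 4; the limit leaves it open whether they differ

Still open, on these data alone, is whether a plain phenyl or a longer chain such as phenylethyl in place of benzyl would give a lower number on both cores. Also open, as far as these compounds go, is how an amine or a carboxylic acid on the benzyl ring would behave.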